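This account rests on a few compounds, and the source may have more. Where it says the series, first, only, none or still open, it means among the compounds named here.

Measured compounds:
compound 1 `CC1(C)[C@H]2CC[C@]1(C)N(Cc1cn(-c3ccc(F)cc3)nn1)C(=O)C2`, 200 nM
compound 2 `CC1(C)[C@H]2CC[C@]1(C)N(Cc1cn(-c3cccc(Br)c3)nn1)C(=O)C2`, 30 nM
compound 3 `CC1(C)[C@H]2CC[C@]1(C)N(Cc1cn(-c3ccccc3Cl)nn1)C(=O)C2`, 40 nM

All three share one core and differ only in the aryl group on an aromatic nitrogen, tested in a functional assay on OVCAR-3 cells (Homo sapiens) for inhibition, read by MTT assay, with a stated time of 24 h; a lower number here means a stronger inhibitor, a higher number a weaker inhibitor. Compound 3 gives 40 nM, the second highest of the three numbers: the nearest gap is a 1.3-fold higher number from compound 2 to compound 3 (0.12 log units; within the scatter), while the furthest is a 5.0-fold lower number from compound 1 to compound 3 (0.70 log units; beyond the scatter). Compound 4 `CC1(C)[C@H]2CC[C@]1(C)N(Cc1cn(-c3ccc(C#N)cc3)nn1)C(=O)C2` carries the change (4-cyanophenyl in place of 2-chlorophenyl on an aromatic nitrogen). Among the compounds with values here, no measured pair involves a nitrile, so the closest guide is compound 1, which bears 4-fluorophenyl, and the steps of a 6.7-fold lower number from compound 1 to compound 2 (0.82 log units; beyond the scatter) and a 5.0-fold lower number from compound 1 to compound 3 (0.70 log units; beyond the scatter) both moved away from that compound. Compound 4 is therefore expected to move back in the direction of compound 1. Compound 4 is expected to show a 3.0-fold higher number from compound 3 to compound 4 (0.48 log units; beyond the scatter), landing at an estimated 120 nM, between 40 nM and 400 nM.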

Compound 4, half-maximal inhibitory concentration: 380 nM
Compound 4: middle estimate off by 3.2-fold (0.50 log units), on the low side; the range from low to high includes it.
By their numbers in this assay, from the lowest: compounds 2 and 3 (each within the scatter of the next); then compounds 1 and 4 (each within the scatter of the next).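

In this assay the swap from 2-chlorophenyl to 4-cyanophenyl loses much activity (a 9.5-fold higher number from compound 3 to compound 4 (0.98 log units; beyond the scatter)), and the comparison with 3-bromophenyl gives a similar picture (a 13-fold higher number from compound 2 to compound 4 (1.10 log units; beyond the scatter)). Replacing fluoro with cyano on the aryl ring stays within the scatter (a 1.9-fold higher number from compound 1 to compound 4 (0.28 log units; within the scatter)), so compound 1 and compound 4 form a weaker pair, apart from compound 2 and compound 3. Nothing available here explains this gap. Still open, on these data alone, is whether 3-cyanophenyl would stand with compound 2 or with compound 4. As far as these compounds go, how an amine or a carboxylic acid on the aryl ring would fare is also open.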